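Swapping a Branched Alkyl for a Dicyclopropylmethylamine

The source may hold more compounds than are shown below. What is called first, only, known or untested is meant among the compounds shown, and "the series" means these compounds.

Compound 1 `CCc1nc(-c2ccc(Cl)cc2Cl)c(CC)nc1CC(CC)CC` was tested in an in vitro ADME assay on microsomes (Rattus norvegicus) for metabolic stability (a lower number here means that the compound disappears faster, a higher number that the compound lasts longer), and gives 0.0417 h. Compound 3 `CCc1nc(-c2ccc(OC)cc2OC(F)(F)F)c(CC)nc1NC(CC)CC` gives 0.0683 h, a number within the usual scatter of that of compound 1, so the two cannot be told apart. Compound 2 `CCc1nc(NC(CC)CC)c(OC)nc1-c1ccc(OC)cc1C(F)(F)F` gives 2 h, far above compound 1 and well beyond the scatter.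

Compound 4 `CCc1nc(-c2ccc(Cl)cc2Cl)c(CC)nc1NC(C1CC1)C1CC1` differs from compound 1 in one place: (dicyclopropylmethyl)amino in place of 2-ethylbutyl on an aromatic carbon. Among the compounds with values here, no measured pair shows exactly this kind of change, so the expectation rests on the spread seen so far. A modest rise is expected, of a size described by a 2.2-fold higher number from compound 1 to compound 4 (0.33 log units; beyond the scatter), because compound 3 gives 0.0683 h while sharing the same short lifetime as compound 1. Compound 4 is therefore estimated at 0.09 h, with a likely range from 0.03 h to 0.35 h.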

Compound 4, half-life: 0.0417 h
For compound 4 the middle estimate is 2.2-fold (0.33 log units) above the measured one; measured number inside the range.
By their numbers in this assay, from the lowest: compounds 1, 4 and 3 (each within the scatter of the next); then compound 2.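

At this position on the shared core, (dicyclopropylmethyl)amino in place of 2-ethylbutyl gives no change at the digits printed from compound 1 to compound 4 (within the scatter) in this assay. Within the data shown here, this is the first one-place comparison, and it shows that adding a nitrogen link, two three-membered rings and a hydrogen-bond donor here does not measurably lengthen the short half-life. Nothing available explains this result. As far as these compounds go, whether a morpholine or a carboxylic acid at the same position would change the half-life remains open. So does whether this swap would give the same result with a different group in place of 2,4-dichlorophenyl.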